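The source may report more compounds than this note shows. Statements on the series, on what has been measured and on what is new or still open speak of the compounds shown alone.

Compound 1, `O=C(O)c1cnc(-c2ccccc2O)[nH]c1=O`, carries a hydroxy group on its phenyl ring. In a functional assay on the whole organism (strain Sprague-Dawley) for inhibition, with Rattus norvegicus as the target, with a stated time of 10 min (a lower number here means that less compound is needed, a higher number that more compound is needed for the effect), compound 1 gives > 5 mg/kg, which is a limit of the assay rather than a measured number; it sits at the limit of > 5 mg/kg in this assay, at which 1 of the 2 values shown sits. Compound 2, `CCCCOc1ccccc1-c1ncc(C(=O)O)c(=O)[nH]1`, has a butyl group on that same oxygen, and in this assay compound 2 gives 0.5 mg/kg. Among the measured compounds shown here, the one measured step here, an at least 10-fold lower number from compound 1 to compound 2 (1.00 log units; beyond the scatter), shows that replacing the hydrogen on that oxygen by a chain lowers the number well beyond the usual scatter.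

Compound 3, `C=CCOc1ccccc1-c1ncc(C(=O)O)c(=O)[nH]1`, has not yet been measured. It differs from compound 1 by allyl in place of hydrogen on an oxygen on an aromatic ring. The allyl group, like the butyl group of compound 2, is a short chain placed on the same oxygen, so the step from compound 1 to compound 2 is the guide. A lowering of similar size is expected, an at least 6.2-fold lower number from compound 1 to compound 3 (0.79 log units; beyond the scatter), and compound 3 is estimated to give about 0.8 mg/kg in this assay, with a likely range from 0.3 mg/kg to 2.5 mg/kg.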

Compound 3, dose for 50% inhibition: 0.5 mg/kg
Compound 3: the middle estimate sits 1.6-fold (0.20 log units) above what was measured; low and high end bracket the measured number.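

Allyl on the oxygen on the aromatic ring also lowers the number in this assay, giving an at least 10-fold lower number from compound 1 to compound 3 (1.00 log units; beyond the scatter), so the gain seen earlier is not unique to butyl. The two chains cannot be told apart in this assay: exchanging propyl for vinyl on the saturated chain carbon bound to that oxygen gives no change at the digits printed from compound 2 to compound 3 (within the scatter), which means that this change, with its double bond outside the aromatic rings, leaves the dose needed within normal repeat variation. The full size of the gain from adding either chain cannot be fixed, because compound 1 has only a limit rather than a measured number: the limit of > 5 mg/kg in this assay, at which 1 of the 3 values shown sits.

The compounds shown leave open how small the group on this oxygen can be while keeping the lower number, as methyl would test, and how large it can grow, as a longer chain such as hexyl would test. They also leave open whether the chain tolerates anything other than carbon and hydrogen, such as an amine or a carboxylic acid at its far end, or a ring, as in benzyl.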